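A few compounds are considered here, and "the series" means these few. Any claim that something is new, unique, unknown or untested is made for them only; others in the source may bear on it.

Measured so far in a functional assay on THP-1 cells (Homo sapiens) for cytotoxicity, read by MTT assay, with a stated time of 72 h; a lower number here means a stronger inhibitor, a higher number a weaker inhibitor

Compound 1 `C=C1CC[C@H]2C(C)(C)CCC[C@]2(C)[C@H]1CCC(C)CC(=O)O` gives 132000 nM
Compound 2 `COc1ccc(/C=C2\CC[C@H]3C(C)(C)CCC[C@]3(C)[C@H]2CCC(C)CC(=O)O)cc1` gives > 200000 nM as a limit only
Compound 3 `CC(CC[C@H]1/C(=C/c2ccc([N+](=O)[O-])cc2)CC[C@H]2C(C)(C)CCC[C@]12C)CC(=O)O` gives 68000 nM

Compound 3 and compound 1 lie within the scatter of each other, while compound 2 reports only a limit. Compound 4 `CC(CC[C@H]1/C(=C/c2ccc(Cl)cc2)CC[C@H]2C(C)(C)CCC[C@]12C)CC(=O)O` carries chloro in place of nitro on an aromatic carbon relative to compound 3. Going by the values given here, the one measured step that bears on this is an at least 2.9-fold lower number from compound 2 to compound 3 (0.46 log units; beyond the scatter) for nitro in place of methoxy. Among the compounds with values here, that step lies beyond the scatter, but its size rests on a limit, and no chloro compound has been measured. The expected step is a 1.3-fold higher number from compound 3 to compound 4 (0.12 log units; within the scatter) and would stay within the scatter in this assay with no clear direction. Compound 4 is estimated at 90000 nM with an expected range from 40000 nM to 180000 nM here.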

Compound 4, half-maximal inhibitory concentration: > 200000 nM
Compound 4 was reported as a limit; the forecaster's own chance of this, stated with the estimate: 15%; middle value at least 2.2-fold (0.34 log units) away from the limit.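

In this assay, chloro in place of nitro on the aromatic carbon gives an at least 2.9-fold higher number from compound 3 to compound 4 (0.46 log units; beyond the scatter), a step that rests on a limit. Among the three groups at this position, nitro alone gives a number, with the methoxy of compound 2 and the chloro of compound 4 both reported only as limits. The step between those two compounds cannot be read, because both values are limits: the limit of > 200000 nM in this assay, at which 2 of the 4 values shown sit.

From the compounds shown here alone, whether an amine or a nitrile on this aromatic carbon would also give a number stays open. So does the effect of moving the nitro group elsewhere on the ring.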